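The source may hold more compounds than are shown below. What is called first, only, known or untested is meant among the compounds shown, and "the series" means these compounds.

In a functional assay on MOLT-4 cells (Homo sapiens) (a higher number here means a weaker inhibitor, a lower number a stronger inhibitor), compound 1 `COc1cc(NC(C)CCCNC(=O)NCCCO)c2ncccc2c1` gives > 100000 nM, which is a limit of the assay and not a number. Compound 2 `COC(=O)NCCCC(C)Nc1cc(OC)cc2cccnc12` gives > 100000 nM, and this too is a limit. Compound 2 therefore has no number of its own from which to measure a step. Compound 3 `CCOC(=O)NCCCC(C)Nc1cc(OC)cc2cccnc12` differs from compound 2 by a single change, (methyl in place of hydrogen on a saturated chain carbon bound to an oxygen next to a carbonyl group), which turns methoxycarbonyl into ethoxycarbonyl. Among the compounds with values here, the only measured step that bears on this is a step that the two limits leave unreadable from compound 1 to compound 2. It also alters the group on the carbonyl carbon, but it gives no size to carry over. The remaining guide is the limit of > 100000 nM in this assay, at which 2 of the 2 values shown sit. Within the data shown here, with no measured step to point otherwise, no shift beyond the scatter is expected in this assay, and the most likely report for the new compound is again a limit. The expected size of the change is a number no higher from compound 2 to compound 3 (the limit leaves the size open). For compound 3 the estimate is 100000 nM, with an expected range from 30000 nM to 300000 nM.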

Compound 3, half-maximal inhibitory concentration: 34000 nM
Beside the measured number, compound 3's estimate is 2.9-fold (0.47 log units) above it, and the stated range covers the measured number.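

In this assay, methyl in place of hydrogen on a saturated chain carbon bound to an oxygen next to a carbonyl group, which turns methoxycarbonyl into ethoxycarbonyl, gives an at least 2.9-fold lower number from compound 2 to compound 3 (0.46 log units; beyond the scatter), so a change of just one carbon at this position is enough to bring a number within the reach of the assay. A swap of the group on the carbonyl carbon gives an at least 2.9-fold lower number from compound 1 to compound 3 (0.46 log units; beyond the scatter), while the step from compound 1 to compound 2 has a limit at both ends and cannot be read. Both readable steps give only a smallest possible size, and compound 3 is the only one of the three compounds with a number of its own, the other two resting at a limit of the assay: the limit of > 100000 nM in this assay, at which 2 of the 3 values shown sit.

As far as these compounds go, how far the true values of compound 1 and compound 2 lie past that limit stays open, and with it the full size of both steps. Also open, from the compounds shown here alone, is whether a longer chain on the oxygen, such as propoxy or butoxy, would lower the number further, or whether a terminal amine on that chain would keep the gain seen with ethoxy.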